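Swapping Chlorophenyl for Dimethylphenyl on the Sulfur Linker

This account rests on a few compounds, and the source may have more. Where it says the series, first, only, none or still open, it means among the compounds named here.

Compound 1 `Cc1cc(C)cc(SCc2ccc(/C=C/C(=O)Nc3ccccc3N)cc2)c1` gives 47.3% in a functional assay on A549 cells (Homo sapiens) for inhibition, read by CCK-8 assay, with a stated time of 72 h, tested at 8 uM; on this read-out higher numbers stand for more inhibition of growth at the one concentration tested and lower numbers for less inhibition of growth.
Compound 2 `Nc1ccccc1NC(=O)/C=C/c1ccc(CSc2ccc(Cl)cc2)cc1` gives 59.6% in this assay.
Compound 3 `Nc1ccccc1NC(=O)c1ccc(CSc2ccc(Cl)cc2)cc1` gives 50.4% in this assay.

Compound 4 `Cc1cc(C)cc(SCc2ccc(C(=O)Nc3ccccc3N)cc2)c1` is not yet measured. The difference between the core of compound 2 and the core of compound 3 is not broken down here. Going from compound 2 to compound 1 the change is 3,5-dimethylphenyl in place of 4-chlorophenyl on a sulfur, and this gave a number 12.3 percentage points lower from compound 2 to compound 1 (beyond the scatter). Compound 4 carries the same change against compound 3, (3,5-dimethylphenyl in place of 4-chlorophenyl on a sulfur), at a place described in the same words, so it counts as the same change. Because the earlier step gave a number 12.3 percentage points lower from compound 2 to compound 1 (beyond the scatter), a step of similar size is expected from compound 3 to compound 4, a number 12.4 percentage points lower from compound 3 to compound 4 (beyond the scatter). Compound 4 is therefore estimated at 38%, expected to fall between 26% and 50%.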

Compound 4, percent growth inhibition at one concentration: 78.5%
Beside the measured number, compound 4's estimate is 40.5 percentage points below it; measured number above the stated range.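

In this assay, putting 3,5-dimethylphenyl in place of 4-chlorophenyl on a sulfur gave a number 28.1 percentage points higher from compound 3 to compound 4 (beyond the scatter). The same swap therefore moved the read-out in opposite directions on the two cores: the same change on two cores in this assay, a number 12.3 percentage points lower (beyond the scatter) from compound 2 to compound 1 and a number 28.1 percentage points higher (beyond the scatter) from compound 3 to compound 4, 40.4 percentage points apart, beyond the scatter of two such steps

This shows that the effect of this swap cannot simply be carried from one of these cores to the other, but it does not show which feature of the cores is responsible, and two pairs of compounds give no rule for any further core. The compounds shown leave open how a plain phenyl or a cyclohexyl group on the sulfur would behave on each core. They also leave open whether the opposite steps would hold at other concentrations or in other cell lines.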